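From isopropylcarbonyl to benzoyl on the shared core

The source may report more compounds than this note shows. Statements on the series, on what has been measured and on what is new or still open speak of the compounds shown alone.

In a functional assay on HCT-116 cells (Homo sapiens) for cytotoxicity, read by sulforhodamine B assay, with a stated time of 48 h (a lower number here means a stronger inhibitor, a higher number a weaker inhibitor), compound 1 (`CCCCNC(=O)N1Cc2c(NC(=O)c3ccccc3)nn(C(=O)c3ccccc3)c2C1`) gives 7470 nM while compound 2 (`CCC(=O)n1nc(NC(=O)c2ccccc2)c2c1CN(C(=O)c1ccccc1)C2`) gives 1060 nM and compound 3 (`CC(C)C(=O)n1nc(NC(=O)c2ccccc2)c2c1CN(C(=O)c1ccccc1)C2`) gives 2020 nM as its result. Compound 3 therefore cannot be told apart from compound 2, since the two lie within the scatter, and compound 1 has a clearly higher number than either.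

The next compound, compound 4 (`O=C(Nc1nn(C(=O)c2ccccc2)c2c1CN(C(=O)c1ccccc1)C2)c1ccccc1`), has phenyl in place of isopropyl on a carbonyl carbon. Going by the values given here, only one measured step bears on this change. It places methyl in place of hydrogen on a saturated chain carbon bound to a carbonyl carbon (a 1.9-fold higher number from compound 2 to compound 3 (0.28 log units; within the scatter)) and stays within the scatter. That is thin evidence for a phenyl group, so the range is kept wide. In this assay the expected step (a 1.2-fold higher number from compound 3 to compound 4 (0.07 log units; within the scatter)) is small, at most a slight rise and nothing beyond the scatter. Compound 4 is expected near 2400 nM within a range of 800 nM to 7000 nM in this estimate.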

Compound 4, half-maximal inhibitory concentration: 1400 nM
Compound 4: middle estimate off by 1.7-fold (0.23 log units), on the high side; measured number inside the range.
By their numbers in this assay, from the lowest: compounds 2, 4 and 3 (each within the scatter of the next); then compound 1.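

In this assay, phenyl in place of isopropyl on a carbonyl carbon gives a 1.4-fold lower number from compound 3 to compound 4 (0.16 log units; within the scatter), and phenyl in place of ethyl gives a 1.3-fold higher number from compound 2 to compound 4 (0.12 log units; within the scatter). So, at this carbonyl carbon bound to an aromatic nitrogen, a six-membered aromatic ring can stand in place of either small chain with no change that can be told from the scatter, while phenyl in place of butylamino on a carbonyl carbon gives a 5.3-fold lower number from compound 1 to compound 4 (0.73 log units; beyond the scatter), a modest step and the only one of these three that is beyond the scatter. Nothing available explains why these numbers fall as they do.

As far as these compounds go, it remains open whether a longer chain, such as hexyl, or an amine on this carbonyl carbon would shift the number clearly. The same question applies to a phenyl ring carrying a methoxy group or a chlorine atom.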